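Cytotoxicity of a Flavone Core with an Altered Side Chain

This account rests on a few compounds, and the source may have more. Where it says the series, first, only, none or still open, it means among the compounds named here.

Measured compounds:
compound 1, `COc1c(OCCCCNCc2ccccc2)cc(O)c2c(=O)cc(-c3ccccc3)oc12`, 4590 nM
compound 2, `COc1c(O)cc(O)c2c(=O)cc(-c3ccc(F)cc3Br)oc12`, "not determined" (no result reported)

Among the measured compounds shown here, compound 1 is the only compound here with a number. In a functional assay on A549 cells (Homo sapiens) for cytotoxicity, read by MTT assay, with a stated time of 48 h (a lower number here means a stronger inhibitor, a higher number a weaker inhibitor), compound 1 gives 4590 nM. Compound 2 shares the core of compound 1 but carries a different side chain and a differently substituted ring on the core; for compound 2 no result was reported, so its two structures say nothing about a step in potency.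

Compound 3, `COc1c(OCCCN2CCNCC2)cc(O)c2c(=O)cc(-c3ccccc3)oc12`, is not yet measured. It differs from compound 1 in one place: piperazin-1-yl in place of (benzylamino)methyl on a saturated chain carbon, three bonds along the chain from an oxygen on an aromatic ring. The (benzylamino)methyl group that leaves is larger and carries an aromatic ring; the piperazin-1-yl group that enters is smaller and ring-bound with two nitrogens. For the measured compounds named here, no step between measured compounds is known, so any expectation rests on compound 1 alone.

Compound 3 is expected to give a value close to that of compound 1, with a step of a 1.4-fold higher number from compound 1 to compound 3 (0.15 log units; within the scatter) that may be toward weaker inhibition but is likely within or near the scatter. For compound 3 the estimated value in this assay is 6500 nM, within a range from 2500 nM to 17000 nM.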

Compound 3, half-maximal inhibitory concentration: 10100 nM
The estimate for compound 3 lay 1.6-fold (0.19 log units) below the measured number; measured number inside the range.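

Putting piperazin-1-yl in place of (benzylamino)methyl on a saturated chain carbon, three bonds along the chain from an oxygen on an aromatic ring, gives in this assay a 2.2-fold higher number from compound 1 to compound 3 (0.34 log units; beyond the scatter) and so shows that the end of this side chain is not silent, although the step is modest. The change weakens the cytotoxic effect without removing it, as compound 3 still gives a measured value in this assay with the shared core unchanged. Nothing available explains this step.

Among the compounds shown here, with a single pair, the loss of the benzene ring cannot be told apart from the exchange of the open-chain amine for a ring with two nitrogens, since both happen in the same change, and compound 2 has no result, so no step to it can be read. From the compounds shown here alone, it remains open how a morpholine, a dimethylamino group or a benzylpiperazine at this chain end would compare, and whether a longer chain carrying the piperazine would shift the value in either direction.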